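Swapping the acyl ring: from compound 1 to compound 4

This account rests on a few compounds, and the source may have more. Where it says the series, first, only, none or still open, it means among the compounds named here.

The study concerns a set of aryl sulfonamide benzanilides tested in a functional assay on HEK293 cells for agonist activity at probable G-protein coupled receptor 27 (Homo sapiens), read by a luciferase reporter and beta-arrestin recruitment, with a stated time of 10 min; on this read-out higher numbers stand for larger maximal responses and lower numbers for smaller maximal responses. Going by the values given here, compound 1, `O=C(Nc1ccc(S(=O)(=O)Nc2ccccc2)cc1)c1cc(F)c(Cl)cc1F`, is the only member for which a number is available: in this assay compound 1 gives 37%. Compound 2, `O=C(Nc1ccc(S(=O)(=O)NCc2ccccc2)cc1)c1ccc(Cl)cc1Cl`, has in this assay only the entry "not determined" (no result reported), and compound 3, `O=C(Nc1ccc(S(=O)(=O)Nc2ncccn2)cc1)c1ccc(Cl)cc1Cl`, has in this assay likewise only the entry "not determined" (no result reported), so compound 1 stands alone on the numbers shown and no comparison between measured compounds can be drawn.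

Compound 4, `O=C(Nc1ccc(S(=O)(=O)Nc2ccccc2)cc1)c1ccc(Cl)cc1Br`, differs from compound 1 in a single place: 2-bromo-4-chlorophenyl in place of 4-chloro-2,5-difluorophenyl on a carbonyl carbon. The 2-bromo-4-chlorophenyl group keeps one aromatic ring without donors or acceptors, as the 4-chloro-2,5-difluorophenyl group did.

Among the compounds with values here, with no step between measured compounds to rest on, the account expects the change from compound 1 to compound 4 to move the maximal response little, if at all, beyond the scatter; the step of a number 3 percentage points higher from compound 1 to compound 4 (within the scatter) is the estimated outcome. In this assay compound 4 is therefore expected to give about 40%, within a range from 20% to 65%.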

Compound 4, largest response reached (Emax), in percent of the reference or control that the assay uses: 123%
Compound 4: the middle estimate sits 83 percentage points below what was measured; the measured number lies above the stated range.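

Placing 2-bromo-4-chlorophenyl where 4-chloro-2,5-difluorophenyl stood on a carbonyl carbon gives, in this assay, a number 86 percentage points higher from compound 1 to compound 4 (beyond the scatter), so this position can strongly shift the maximal response. The size of the step does not follow the counts for the two groups: each has one six-membered aromatic ring of carbon only and no hydrogen-bond donors or acceptors. No measured evidence at hand bears on the reason for the size of this step.

The pair cannot separate the entry of bromine from the loss of the two fluorines, as both changes occur in one step. It also leaves open how the maximal response would respond to a methoxy group, a nitrile or a carboxylic acid on this aromatic ring.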